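This account rests on a few compounds, and the source may have more. Where it says the series, first, only, none or still open, it means among the compounds named here.

Compound 1 `CCCN(CCC)c1nc(N2CCN(C(=O)c3ccco3)[C@@H]3CCCC[C@@H]32)nc2cc(OC)c(OC)cc12` was tested in a functional assay (strain Wistar) for antagonist activity at Alpha-1A adrenergic receptor (Rattus norvegicus), with stated times of 30 min and 45 min, in the presence of a further agent that is not named here (on this read-out lower numbers stand for lower potency and higher numbers for higher potency (the scale is a negative logarithm)), where compound 1 gives 7.02. Among the compounds with values here, only one other compound has a number: compound 2 `COc1cc2nc(N3CCN(C(=O)C(C)(C)C)[C@H]4CCCC[C@H]43)nc(N)c2cc1OC` gives 7.17 in this assay, and the two values lie within the usual scatter of each other, so compound 1 stands level with its sole companion. Compound 3 `CCCN(CCC)c1nc(N2CCN(C(=O)c3ccco3)[C@H]3CCCC[C@H]32)nc2cc(OC)c(OC)cc12` is the mirror image of compound 1: the two compounds have the same atoms and bonds and differ only in configuration as drawn: 2 of 2 stereo elements differ (all stereocentres are inverted: mirror images); a stereocentre at a saturated ring carbon is drawn R in compound 1 and S in compound 3; a stereocentre at a saturated ring carbon is drawn S in compound 1 and R in compound 3. Within the data shown here, no measured pair shows what such an inversion does here, so the expected step from compound 1 to compound 3 is a number 0.08 log units higher from compound 1 to compound 3 (within the scatter), with no direction favoured beyond the scatter. The estimate for compound 3 in this assay is 7.1, within 6.3 to 7.9.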

Compound 3, negative logarithm of the antagonist equilibrium constant: 5.89
Beside the measured number, compound 3's estimate is 1.21 log units above it; measured number outside the range, below it.
By their numbers in this assay, from the lowest: compound 3; then compounds 1 and 2 (each within the scatter of the next).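

In this assay, inverting both stereocentres at the saturated ring carbons gives a number 1.13 log units lower from compound 1 to compound 3 (beyond the scatter), the first sign that this read-out depends on configuration at these carbons. Within the data shown here, earlier, no measured pair isolated such an inversion. The drop can be assigned to configuration alone because no atom or bond changes: the fact that compounds 1 and 3 differ only in the configuration as drawn.

From the compounds shown here alone, it remains open how a compound with only one of these stereocentres inverted would compare. It is also unclear whether the same preference would hold with a benzoyl group in place of the acyl group of compound 1.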